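A few compounds are considered here, and "the series" means these few. Any claim that something is new, unique, unknown or untested is made for them only; others in the source may bear on it.

In a functional assay on SW-620 cells (Homo sapiens) for cytotoxicity, read by MTT assay, with a stated time of 72 h (a higher number here means a weaker inhibitor, a lower number a stronger inhibitor), compound 1 (`COc1ccc(/C=C2\CCC/C(=C\c3ccccc3Cl)C2=O)cc1OC`) gives 7100 nM and compound 2 (`COc1ccc(/C=C2\CCC/C(=C\c3cccc(Cl)c3)C2=O)cc1OC`) gives 5100 nM. Within the data shown here, compound 2 therefore stands level with compound 1, the only other compound measured so far. Compound 3 (`COc1ccc(/C=C2\CCC/C(=C\c3ccc(Cl)cc3)C2=O)cc1OC`) has the same atoms as compound 2, joined differently: 4-chlorophenyl in place of 3-chlorophenyl on a double-bonded chain carbon bound to a double-bonded ring carbon. The change falls on a double-bonded chain carbon bound to a double-bonded ring carbon, where 4-chlorophenyl takes the place of 3-chlorophenyl. Among the measured compounds shown here, the one measured step at this place, a 1.4-fold lower number from compound 1 to compound 2 (0.14 log units; within the scatter), also exchanges one chlorophenyl for another and stays within the scatter. For the measured compounds named here, it is only a single step, so it offers limited guidance, but on this evidence no change beyond the scatter is expected in this assay. The expected step is a 1.1-fold higher number from compound 2 to compound 3 (0.03 log units; within the scatter). Compound 3 is estimated at 5500 nM, with an expected range from 2500 nM to 12000 nM.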

Compound 3, half-maximal inhibitory concentration: 5900 nM
Beside the measured number, compound 3's estimate is 1.1-fold (0.03 log units) below it; measured number inside the range.
By their numbers in this assay, from the lowest: compounds 2, 3 and 1 (each within the scatter of the next).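

In this assay the third chlorophenyl completes the series at this place, with a 1.2-fold higher number from compound 2 to compound 3 (0.06 log units; within the scatter) and a 1.2-fold lower number from compound 1 to compound 3 (0.08 log units; within the scatter) as the two new steps. Where the earlier compounds offered one exchange of chlorophenyl groups, all three pairs can now be read, and 2-chlorophenyl, 3-chlorophenyl and 4-chlorophenyl on a double-bonded chain carbon bound to a double-bonded ring carbon cannot be told apart in this assay, so shifting the chlorine around this ring does not separate these compounds. Nothing available here accounts for this result.

The compounds shown leave open whether an amine or a carboxylic acid in place of the chlorine would carry the number beyond the scatter. They also leave open how the number responds to changes elsewhere on the shared core.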